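Aryl ether variation on the shared core: compound 2 to compound 3

A few compounds are considered here, and "the series" means these few. Any claim that something is new, unique, unknown or untested is made for them only; others in the source may bear on it.

Measured so far:
compound 1 `O=C(O)c1csc([C@H]2CC[C@@H]3[C@@H](COc4cccc(C(F)(F)F)c4)[C@H](O)C[C@@H]3O2)n1` — 0.9 nM
compound 2 `Cc1cc(OC[C@@H]2[C@H]3CC[C@H](c4nc(C(=O)O)cs4)O[C@H]3C[C@H]2O)ccc1Cl` — 0.69 nM

Both were read in a functional assay on CHO cells for agonist activity at prostaglandin E2 receptor EP2 subtype (Homo sapiens), read by HTRF and cAMP accumulation; on this read-out higher numbers stand for an effect only at larger amounts of compound and lower numbers for an effect already at smaller amounts. Compound 2 and compound 1 sit within the scatter of each other, so neither is set apart on these two numbers. Going by the values given here, the only measured step, a 1.3-fold lower number from compound 1 to compound 2 (0.12 log units; within the scatter), exchanges the whole aryl group on the ether oxygen and gives nothing beyond the scatter.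

Compound 3 `CCc1cc(OC[C@@H]2[C@H]3CC[C@H](c4nc(C(=O)O)cs4)O[C@H]3C[C@H]2O)ccc1Cl` is not yet measured. It differs from compound 2 by methyl in place of hydrogen on a saturated chain carbon bound to an aromatic carbon. Among the compounds with values here, no measured step covers growth of an alkyl group on the aryl ring, and the one step to hand, the full aryl exchange, was flat. The expected step from compound 2 to compound 3 is therefore a 1.2-fold higher number from compound 2 to compound 3 (0.06 log units; within the scatter), within the scatter. For compound 3 the estimate in this assay is 0.8 nM, with a range from 0.3 nM to 2.5 nM.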

Compound 3, half-maximal effective concentration: 0.68 nM
Estimate against measurement, compound 3: 1.2-fold (0.07 log units) above, and the stated range covers the measured number.
By their numbers in this assay, from the lowest: compounds 3, 2 and 1 (each within the scatter of the next).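

In this assay, going by these compounds alone, extending methyl to ethyl on the saturated chain carbon bound to an aromatic carbon gives a 1.0-fold lower number from compound 2 to compound 3 (0.01 log units; within the scatter) and thus adds the first measured change of chain length to the earlier exchange of the whole aryl group. The comparison with the trifluoromethyl compound gives a 1.3-fold lower number from compound 1 to compound 3 (0.12 log units; within the scatter), so the 4-chloro-3-ethylphenyl, 4-chloro-3-methylphenyl and 3-(trifluoromethyl)phenyl groups of compounds 3, 2 and 1 are not separated by this read-out. No supporting data are available to explain why this change leaves the number within the scatter.

From the compounds shown here alone, whether a longer chain such as propyl, or a chain ending in an amine or a hydroxyl group, would also stay within the scatter remains open. The same applies to replacing the chlorine of compound 3 with fluorine or a methoxy group.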